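Bromo for pyridin-3-yl: a working note

The source may report more compounds than this note shows. Statements on the series, on what has been measured and on what is new or still open speak of the compounds shown alone.

In a functional assay on KG-1 cells (Homo sapiens) for cytotoxicity, read by luminescence and CellTiter-Glo, with a stated time of 3 days (on this read-out lower numbers stand for stronger inhibition and higher numbers for weaker inhibition), compound 1 (`O=C(Nc1ccc(Cl)cc1Cl)c1cc(F)ccc1O`) gives 850 nM and compound 2 (`N#Cc1ccc(NC(=O)c2cc(-c3cccnc3)ccc2O)cc1`) gives 8330 nM. Compound 2 therefore holds the higher of the two numbers, with a gap beyond the usual scatter. These two compounds differ in more than one place, so their gap cannot be read as the effect of any single change. Compound 3 (`N#Cc1ccc(NC(=O)c2cc(Br)ccc2O)cc1`) differs from compound 2 in one place: bromo in place of pyridin-3-yl on an aromatic carbon. A moderate step towards a lower number is expected in this assay, probably beyond the scatter. The only support is thin: compound 1, which has no pyridin-3-yl, gives 850 nM. The expected change is a 3.3-fold lower number from compound 2 to compound 3 (0.52 log units; beyond the scatter). For compound 3 the estimate is 2500 nM, with an expected range of 800 nM to 8000 nM.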

Compound 3, half-maximal inhibitory concentration: 1290 nM
For compound 3 the middle estimate is 1.9-fold (0.29 log units) above the measured one; the range from low to high includes it.
By their numbers in this assay, from the lowest: compounds 1 and 3 (each within the scatter of the next); then compound 2.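

In this assay the place para to a hydroxy group responds to a single change: bromo in place of pyridin-3-yl gives a 6.5-fold lower number from compound 2 to compound 3 (0.81 log units; beyond the scatter), the first gap in the series that can be tied to one place. An aromatic ring at this aromatic carbon is therefore not needed to hold activity, since compound 3, with no ring there, gives 1290 nM in this assay. No data on hand account for the size of this step.

As far as these compounds go, whether an amine, a carboxylic acid or a longer chain at the same place would move the number further remains open. Also open, from the compounds shown here alone, is whether the same exchange would give a similar step on the core of compound 1.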